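The compounds below may be only part of what the source reports. "The series", "measured", "known", "first", "only" and "open" are said of these compounds alone.

Compound 1, `CNCc1cn(S(=O)(=O)c2cccs2)c(-c2cccnc2F)c1F`, gives 98% in a functional assay on the whole organism (strain Jcl:Sprague-Dawley) for inhibition, with Rattus norvegicus as the target, with stated times of 3 min and 3 h, at a dose of 1 mg/kg by the intravenous route; a higher number here means more inhibition at the dose given (going by the name of the read-out), a lower number less inhibition.
Compound 2, `CNCc1cn(S(=O)(=O)c2ccco2)c(-c2cccnc2F)c1F`, gives 75%.
Compound 3, `CNCc1cn(S(=O)(=O)c2cccc(OC)n2)c(-c2cccnc2F)c1F`, gives 98%.

Compound 3 stands level with compound 1 at the digits printed, and together they hold the highest of the three numbers. Its nearest neighbour is compound 1, with no change at the digits printed from compound 1 to compound 3 (within the scatter); the furthest is compound 2, with a number 23 percentage points higher from compound 2 to compound 3 (beyond the scatter).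

Compound 4, `CNCc1cn(S(=O)(=O)c2ccc(OC)cn2)c(-c2cccnc2F)c1F`, differs from compound 3 in one place: 5-methoxypyridin-2-yl in place of 6-methoxypyridin-2-yl on a sulfonyl sulfur. Among the compounds with values here, no measured step moves the methoxy group within the pyridine ring, so none bears on this change directly. What the measured steps do show is how far the read-out moves when the whole group on the sulfonyl sulfur is exchanged: a number 23 percentage points lower from compound 1 to compound 2 (beyond the scatter) and a number 23 percentage points higher from compound 2 to compound 3 (beyond the scatter), each modest, while no change at the digits printed from compound 1 to compound 3 (within the scatter). Since a change of the whole group never moved the number more than modestly, a shift of the methoxy within the same ring is expected to give a step of a number 8 percentage points lower from compound 3 to compound 4 (within the scatter), small and, if anything, downward. Compound 4 is therefore estimated at 90%, with a range from 70% to 99%.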

Compound 4, a percentage reported as inhibition, in the whole organism at one dose (the size of the read-out at that dose, not a potency): 95%
Beside the measured number, compound 4's estimate is 5 percentage points below it; the measured number falls inside the stated range.
By their numbers in this assay, from the lowest: compound 2; then compounds 4, 1 and 3 (each within the scatter of the next).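

In this assay, moving the methoxy group within the same pyridine ring on the sulfonyl sulfur gives a number 3 percentage points lower from compound 3 to compound 4 (within the scatter), so this read-out does not separate 5-methoxypyridin-2-yl from 6-methoxypyridin-2-yl. The 5-methoxypyridin-2-yl group likewise gives a number 3 percentage points lower from compound 1 to compound 4 (within the scatter) against thiophen-2-yl, while against furan-2-yl it gives a number 20 percentage points higher from compound 2 to compound 4 (beyond the scatter). Of the four groups on the sulfonyl sulfur, only the furan-2-yl of compound 2 stands apart, and nothing given here bears on the reason for this.

On these data alone, it remains open whether an amine or a carboxylic acid in place of the methoxy group on this pyridine ring would keep the inhibition. Also open, as far as these compounds go, is whether compound 1, compound 3 and compound 4 would separate at a lower dose, since a reading at one dose is not a potency.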